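Hydrazone aryl swap on a triazole thioether scaffold

The source may report more compounds than this note shows. Statements on the series, on what has been measured and on what is new or still open speak of the compounds shown alone.

Measured so far:
Compound 1 `c1ccc(CSc2nnc(-c3ccncc3)n2-c2ccccc2)cc1`: 12900 nM
Compound 2 `O=C(CSc1nnc(-c2ccncc2)n1-c1ccccc1)N/N=C/c1ccc(Br)cc1`: 5990 nM

Both compounds were tested in a functional assay on HepG2 cells (Homo sapiens) for inhibition, read by MTT assay, with a stated time of 48 h; a lower number here means a stronger inhibitor, a higher number a weaker inhibitor. Compound 1 gives 12900 nM in this assay, and compound 2 gives 5990 nM. Compound 2 therefore holds the lowest of the two numbers; the number of compound 1 is higher, and the gap between them lies beyond the usual scatter of this kind of measurement. Among the measured compounds shown here, no pair of measured compounds differs in only one place, so no single step has yet been isolated.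

Compound 3 `O=C(CSc1nnc(-c2ccncc2)n1-c1ccccc1)N/N=C/c1ccccc1O` is the next compound to be examined. It differs from compound 2 by 2-hydroxyphenyl in place of 4-bromophenyl on a carbon with a double bond to nitrogen. For the measured compounds named here, nothing among the measured compounds shows what such an exchange does in this assay, so the expected step is small: no change beyond the scatter in either direction, with the wide range that this uncertainty demands. The estimate for compound 3 in this assay is 7000 nM, within a range from 2500 nM to 20000 nM. This estimate corresponds to an expected step of a 1.2-fold higher number from compound 2 to compound 3 (0.07 log units; within the scatter).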

Compound 3, half-maximal inhibitory concentration: 11300 nM
Estimate against measurement, compound 3: 1.6-fold (0.21 log units) below; measured number inside the range.
By their numbers in this assay, from the lowest: compounds 2, 3 and 1 (each within the scatter of the next, the first and the last beyond it).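

In this assay, putting 2-hydroxyphenyl in place of 4-bromophenyl on a carbon with a double bond to nitrogen gives a 1.9-fold higher number from compound 2 to compound 3 (0.28 log units; within the scatter), the first single-place step available in this series. This exchange keeps the count of seven heavy atoms, replaces bromine with oxygen and brings in one hydrogen-bond donor and one hydrogen-bond acceptor where the leaving group has neither, yet the two numbers cannot be told apart in this assay, so this one exchange at this position leaves no effect that can be separated from the scatter. Nothing available here offers an independent measurement that bears on this result.

Going by these compounds, with only these two groups compared at this position, it remains open whether a plain phenyl, a dimethylamino group or a carboxylic acid in the same place would give a number beyond the scatter of compound 2. On these data alone, compound 1 differs from both compound 2 and compound 3 in more than one place, so what the rest of their shared structure contributes also remains open.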